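Removing the Acetoxy Group from a Brominated Butenolide

The source may hold more compounds than are shown below. What is called first, only, known or untested is meant among the compounds shown, and "the series" means these compounds.

Measured compounds:
- Compound 1 `CCC[C@@H](OC(C)=O)C1=C(Br)/C(=C/Br)OC1=O`, in a functional assay on HT-1080 cells (Homo sapiens) for cytotoxicity (a higher number here means that more compound is needed for the effect, a lower number that less compound is needed), compound 1 gives "not determined" (no result reported).
- Compound 2 `CCCCCCC(=O)C(Br)=C(Br)Br`, in this assay compound 2 gives > 20 ug/mL, which is a limit of the assay and not a number.
- Compound 3 `CCCCC1=C(Br)C(OC)(C(Br)Br)OC1=O`, in this assay compound 3 gives "not determined" (no result reported).

Compound 1 therefore has no single number of its own in this assay. Among the other two entries, one is an entry without a number, and one is a limit: the limit of > 20 ug/mL in this assay, at which 1 of the 3 values shown sits. So the only reading available is that compound 2 needed more than that limit to reach the half-maximal effect, while nothing is known numerically about compound 1 or compound 3.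

The unmeasured compound 4 `CCCCC1=C(Br)/C(=C/Br)OC1=O` shares the core of compound 1 and differs from it in one place: hydrogen in place of acetoxy on a saturated chain carbon bound to a double-bonded ring carbon and a saturated chain carbon.

Among the compounds with values here, no measured pair differs in a single place, so no step size can be read from the data. With no number for compound 1, I expect the step in this assay from compound 1 to compound 4 to be none beyond the usual scatter, in no particular direction.

For compound 4 in this assay, I estimate 25 ug/mL, with a range from 6 ug/mL to 100 ug/mL, and a fair chance that only a limit is reported.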

Compound 4, concentration for half-maximal effect: 2.2 ug/mL
Compound 4: the middle estimate sits 11-fold (1.06 log units) above what was measured; the whole stated range lies above it.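

In this assay, within the data shown here, compound 1 gives "not determined" (no result reported) and compound 4 gives 2.2 ug/mL here, so no step from compound 1 to compound 4 can be read. The compounds shown leave open whether replacing acetoxy with hydrogen changes how much compound is needed for the effect, and by how much. Nothing shown here accounts for the value of compound 4.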